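Diol side chain in place of cyanomethyl on the amide

The source may report more compounds than this note shows. Statements on the series, on what has been measured and on what is new or still open speak of the compounds shown alone.

Compound 1 `CCn1c(C(=O)NCC#N)ccc1C(CC)(CC)c1ccc(OCCC(O)(CC)CC)c(C)c1` stands at a limit of the assay: in a functional assay on Caco-2 cells (Homo sapiens) for antiproliferative activity, read by MTT assay, with a stated time of 48 h (on this read-out lower numbers stand for stronger inhibition and higher numbers for weaker inhibition), compound 1 gives > 50000 nM, a limit and not a number. Compound 2 `CCC(C)C(NC(=O)c1ccc(C(CC)(CC)c2ccc(OCCC(O)(CC)CC)c(C)c2)n1CC)C(=O)O` gives 20000 nM in this assay. Compound 3 `CCC(C)C(CO)NC(=O)c1ccc(C(CC)(CC)c2ccc(OCCC(O)(CC)CC)c(C)c2)n1CC` gives > 50000 nM, again a limit. Compound 4 `CCn1c(C(=O)NC(CO)CCO)ccc1C(CC)(CC)c1ccc(OCCC(O)(CC)CC)c(C)c1` differs from compound 1 by 3-hydroxy-1-(hydroxymethyl)propyl in place of cyanomethyl on an amide-type nitrogen. Among the measured compounds shown here, two steps bear on it: an at least 2.5-fold lower number from compound 1 to compound 2 (0.39 log units; beyond the scatter) brought a carboxy-bearing chain below the limit, whereas an at least 2.5-fold higher number from compound 2 to compound 3 (0.39 log units; beyond the scatter) went back to the limit on exchange of carboxy for hydroxymethyl, and a step that the two limits leave unreadable from compound 1 to compound 3 stayed unreadable, both compounds sharing (the limit of > 50000 nM in this assay, at which 2 of the 3 values shown sit). Compound 4 carries hydroxyls and no carboxy, so no step beyond the scatter is expected, and compound 4 is estimated at 60000 nM (range 25000 nM to 200000 nM), a step that the limit leaves unreadable from compound 1 to compound 4, most likely reported again as a limit.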

Compound 4, half-maximal inhibitory concentration: 40200 nM
Estimate against measurement, compound 4: 1.5-fold (0.17 log units) above; low and high end bracket the measured number.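

In this assay, the 3-hydroxy-1-(hydroxymethyl)propyl chain on the amide-type nitrogen gives compound 4 a measured number with no carboxy present, so a carboxy is not needed for a value off the limit: the limit of > 50000 nM in this assay, at which 2 of the 4 values shown sit. The gain over the limit compounds remains unproven, with an at least 1.2-fold lower number from compound 1 to compound 4 (0.09 log units; that floor lies within the scatter) and an at least 1.2-fold lower number from compound 3 to compound 4 (0.09 log units; that floor lies within the scatter). Against the carboxy chain, the data show a 2.0-fold higher number from compound 2 to compound 4 (0.30 log units; within the scatter), so the two chains cannot be told apart here.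

Open, as far as these compounds go, is whether an amine or a longer diol chain on this nitrogen would move the number beyond the scatter of compound 2 and compound 4.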